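The source may hold more compounds than are shown below. What is called first, only, known or untested is meant among the compounds shown, and "the series" means these compounds.

Of the compounds shown here, three have so far been measured in an ADME assay (Rattus norvegicus, strain Wistar Han) for pharmacokinetics; on this read-out lower numbers stand for narrower distribution and higher numbers for wider distribution into tissues. Compound 1, `CCn1c(-c2cnc(C)nc2)nc2c(N[C@H]3CCN(C(=O)C4CC(F)(F)C4)C3)ncnc21`, gives 0.9 L/kg. Compound 2, `CCC(=O)N1CC[C@H](Oc2ncnc3c2nc(-c2cnc(C)nc2)n3CC)C1`, gives 1.2 L/kg, and compound 3, `CCn1c(-c2ccc(C(F)(F)F)nc2)nc2c(O[C@H]3CCN(C(=O)c4cocn4)C3)ncnc21`, gives 0.3 L/kg. Among these three numbers compound 1 stands second highest; the value of compound 2 lies within the usual scatter of that of compound 1, so no order between those two can be read, while compound 3 sits beyond the scatter below compound 1.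

Compound 4, `CCn1c(-c2cnc(C)nc2)nc2c(N[C@H]3CCN(C(=O)[C@H]4C[C@@H](OC)C4)C3)ncnc21`, has not yet been measured. It differs from compound 1 in one place: 3-methoxycyclobutyl in place of 3,3-difluorocyclobutyl on a carbonyl carbon. The rest of compound 1 is carried over unchanged. Among the compounds with values here, no pair of measured compounds differs by this change alone, so there is no measured step on which the size of the change can be read. In this assay the step of no change at the digits printed from compound 1 to compound 4 (within the scatter) is expected to stay within the scatter, in neither direction. Compound 4 is accordingly estimated at 0.9 L/kg, with a range from 0.5 L/kg to 1.6 L/kg.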

Compound 4, volume of distribution: 1.5 L/kg
The estimate for compound 4 lay 1.7-fold (0.22 log units) below the measured number; the measured number falls inside the stated range.
By their numbers in this assay, from the lowest: compound 3; then compounds 1, 2 and 4 (each within the scatter of the next).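

In this assay, within the data shown here, 3-methoxycyclobutyl in place of 3,3-difluorocyclobutyl on a carbonyl carbon gives a 1.7-fold higher number from compound 1 to compound 4 (0.22 log units; within the scatter) and is the first step measured at this place. With the rest of compound 1 unchanged, a group with one hydrogen-bond acceptor can thus replace one with none, at the same count of heavy atoms, without the read-out leaving the scatter. Nothing measured here speaks to why the step has this size.

One step at one place cannot show whether an amine or a carboxylic acid on the cyclobutyl ring would carry the number beyond the scatter. As far as these compounds go, it also remains open how the other stereoisomer of the 3-methoxycyclobutyl group would read, and whether the same change would give a similar step on another core.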